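The source may report more compounds than this note shows. Statements on the series, on what has been measured and on what is new or still open speak of the compounds shown alone.

Compound 1 `COc1cc(/C=C2\CN(C)C/C(=C\c3ccccc3F)C2=O)cc(OC)c1OC`: 4340 nM
Compound 2 `COc1cc(/C=C2\CN(C)C/C(=C\c3ccc(Cl)c(Cl)c3)C2=O)cc(OC)c1OC`: 16200 nM

In a functional assay on K562 cells (Homo sapiens) for cytotoxicity, read by MTT assay, with a stated time of 24 h (a lower number here means a stronger inhibitor, a higher number a weaker inhibitor), compound 2 has the higher of the two numbers, at 16200 nM. Compound 3 `COc1cc(/C=C2\CN(C)C/C(=C\c3cccc([N+](=O)[O-])c3)C2=O)cc(OC)c1OC` differs from it as follows: 3-nitrophenyl in place of 3,4-dichlorophenyl on a double-bonded chain carbon bound to a double-bonded ring carbon. In words, it has 3-nitrophenyl in place of 3,4-dichlorophenyl on a double-bonded chain carbon bound to a double-bonded ring carbon. Going by the values given here, only one measured step changes this same place: a 3.7-fold higher number from compound 1 to compound 2 (0.57 log units; beyond the scatter). Among the compounds with values here, no measured compound carries the 3-nitrophenyl group, so this is a loose guide, but a modest step toward a lower number is expected. The expected step is a 2.2-fold lower number from compound 2 to compound 3 (0.33 log units; beyond the scatter). For compound 3 the estimate is 7500 nM, with an expected range of 2500 nM to 20000 nM.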

Compound 3, half-maximal inhibitory concentration: 4200 nM
Beside the measured number, compound 3's estimate is 1.8-fold (0.25 log units) above it; measured number inside the range.
By their numbers in this assay, from the lowest: compounds 3 and 1 (each within the scatter of the next); then compound 2.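

In this assay the place on the double-bonded chain carbon accepts a 3-nitrophenyl group as readily as a 2-fluorophenyl group (a 1.0-fold lower number from compound 1 to compound 3 (0.01 log units; within the scatter)), whereas replacing 3,4-dichlorophenyl with 3-nitrophenyl clearly lowers the number (a 3.9-fold lower number from compound 2 to compound 3 (0.59 log units; beyond the scatter)). The high number of compound 2 is therefore not shared by every substituted phenyl group here, and among these three compounds only 3,4-dichlorophenyl stands apart. No available evidence explains this difference. Still open, from the compounds shown here alone, is whether a phenyl group carrying an amine or a carboxylic acid would stay level with compound 1 and compound 3.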